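Chloro to methoxy on the aryl ketone of compound 1

This account rests on a few compounds, and the source may have more. Where it says the series, first, only, none or still open, it means among the compounds named here.

Compound 1 `COc1cc(-c2nnc3n2NC(c2ccco2)C(C(=O)c2ccc(Cl)cc2)S3)cc(OC)c1OC` stands second highest of three numbers in a functional assay on A549 cells (Homo sapiens) for cytotoxicity, read by MTT assay, with a stated time of 48 h (on this read-out higher numbers stand for weaker inhibition and lower numbers for stronger inhibition), giving 51400 nM there. Compound 3 `COc1cc(-c2nnc3n2NC(c2cccs2)C(C(=O)c2ccccc2)S3)cc(OC)c1OC` gives 69400 nM, within the scatter of compound 1, while compound 2 `COc1cc(-c2nnc3n2NC(c2cccs2)C(C(=O)c2ccc(C)cc2)S3)cc(OC)c1OC` gives 12700 nM, beyond it. Among the measured compounds shown here, the single one-point step measured is a 5.5-fold higher number from compound 2 to compound 3 (0.74 log units; beyond the scatter), which shows the group on the aryl ketone ring does matter. Compound 4 `COc1ccc(C(=O)C2Sc3nnc(-c4cc(OC)c(OC)c(OC)c4)n3NC2c2ccco2)cc1` differs from compound 1 by methoxy in place of chloro on an aromatic carbon. For the measured compounds named here, no measured pair exchanges chloro for methoxy, so that step bears only indirectly. A shift within the scatter is expected in either direction, with the expected step being a 1.1-fold lower number from compound 1 to compound 4 (0.06 log units; within the scatter) for compound 4. Compound 4 is therefore estimated at 45000 nM, between 15000 nM and 130000 nM in range.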

Compound 4, half-maximal inhibitory concentration: > 100000 nM
Compound 4: only a limit was reported; the forecaster's own chance of this, stated with the estimate: 15%; middle value at least 2.2-fold (0.34 log units) away from the limit.
By their numbers in this assay, from the lowest: compound 2; then compounds 1 and 3 (each within the scatter of the next). At a limit, above all of these: compound 4.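

Compound 4 is reported only as a limit in this assay: the limit of > 100000 nM in this assay, at which 1 of the 4 values shown sits. Going by these compounds, the change from chloro to methoxy gives an at least 1.9-fold higher number from compound 1 to compound 4 (0.28 log units; that floor lies within the scatter), so the floor alone does not separate the pair, and the true size of the step stays unknown. Even so, this first one-place change on the core of compound 1 shows that methoxy on this carbon brings no measurable gain over chloro.

Still open, on these data alone, is how far compound 4 truly lies from compound 1. Also open, as far as these compounds go, is how an amine or a carboxylic acid on this carbon would read.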